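Oxazole for Imidazole on the Shared Core

The source may hold more compounds than are shown below. What is called first, only, known or untested is meant among the compounds shown, and "the series" means these compounds.

Going by the values given here, compound 1 `CC(C)C(c1ncc[nH]1)c1ccc(-c2ccc3cccc(F)c3c2)[nH]c1=O` is one of three compounds measured in a functional assay on CHO cells for antagonist activity at prostaglandin E2 receptor EP3 subtype (Homo sapiens), read by cAMP accumulation (a higher number here means a weaker inhibitor, a lower number a stronger inhibitor), where compound 1 gives 33 nM. Compound 2 `CC(C)C(c1ccc(-c2ccc3cccc(F)c3c2)[nH]c1=O)N1CCNC1=O` gives 28 nM, and compound 3 `CC(C)C(Cc1nnn[nH]1)c1ccc(-c2ccc3cccc(F)c3c2)[nH]c1=O` gives 134 nM. Compound 1 sits with compound 2 within the scatter, since a 1.2-fold lower number from compound 1 to compound 2 (0.07 log units; within the scatter), and apart from compound 3, since a 4.1-fold higher number from compound 1 to compound 3 (0.61 log units; beyond the scatter). Compound 4 `CC(C)C(c1ncco1)c1ccc(-c2ccc3cccc(F)c3c2)[nH]c1=O` is not yet measured; it differs from compound 1 thus: 1,3-oxazol-2-yl in place of 1H-imidazol-2-yl on a saturated chain carbon bound to an aromatic carbon and a saturated chain carbon. Among the compounds with values here, no measured step exchanges one five-membered aromatic ring for another at this place. The steps of a 1.2-fold lower number from compound 1 to compound 2 (0.07 log units; within the scatter) and a 4.8-fold higher number from compound 2 to compound 3 (0.68 log units; beyond the scatter) show that substitution here moves the number by at most a modest amount. The expected step is therefore a 1.8-fold higher number from compound 1 to compound 4 (0.26 log units; within the scatter). Compound 4 is estimated at 60 nM, with a range from 25 nM to 180 nM.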

Compound 4, half-maximal inhibitory concentration: 64 nM
The estimate for compound 4 lay 1.1-fold (0.03 log units) below the measured number; low and high end bracket the measured number.
By their numbers in this assay, from the lowest: compounds 2, 1 and 4 (each within the scatter of the next, the first and the last beyond it); then compound 3.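

With a step of a 1.9-fold higher number from compound 1 to compound 4 (0.29 log units; within the scatter), the 1,3-oxazol-2-yl ring, with 0 hydrogen-bond donors, stays within the scatter of the 1H-imidazol-2-yl ring, with 1, so in this assay this pair shows that the ring's donor is not required at this place. Compound 4 still stands apart from both other groups, with steps of a 2.1-fold lower number from compound 3 to compound 4 (0.32 log units; beyond the scatter) and a 2.3-fold higher number from compound 2 to compound 4 (0.36 log units; beyond the scatter). The compounds shown leave open whether a 1,3-thiazol-2-yl ring or a carboxylic acid on the same saturated chain carbon would hold the number. No measurement here explains these steps.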